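Exchanging an Oxadiazole Side Chain for a Furan Side Chain

The source may report more compounds than this note shows. Statements on the series, on what has been measured and on what is new or still open speak of the compounds shown alone.

Compound 1, `Cc1ccc([C@H](CCO)n2cc(-c3ccnc4ccccc34)nn2)cc1`, in an assay on CHO cells for displacement of a labelled ligand from Orexin/Hypocretin receptor type 1 (Homo sapiens), read by radioligand binding, with a stated time of 2 h (a lower number here means a stronger inhibitor, a higher number a weaker inhibitor), gives > 100000 nM, an assay limit rather than a number.
Compound 2, `Cc1cc([C@@H]2CCCCN2C(=O)c2ccc(-c3cc[nH]n3)cc2)no1`, gives > 100000 nM, also a limit.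
Compound 3, `COc1cc(=O)n2c(c1C(=O)N(C)Cc1nonc1C)CCN(C(=O)C1(c3ccccc3)CC1)CC2`, gives > 100000 nM, again only a limit.

Compound 3 therefore stands where every measured compound stands: at the limit of > 100000 nM in this assay, at which 3 of the 3 values shown sit. Going by the values given here, no pair of measured compounds differs in a single place, so no measured step is available to guide a prediction. Compound 4, `COc1cc(=O)n2c(c1C(=O)N(C)[C@H](C)c1ccco1)CCN(C(=O)C1(c3ccccc3)CC1)CC2`, differs from compound 3 by 1-(furan-2-yl)ethyl in place of (4-methyl-1,2,5-oxadiazol-3-yl)methyl on an amide-type nitrogen. With compound 3 showing only > 100000 nM, compound 4 is expected to stay at or near that limit, with no shift beyond the usual scatter. The estimate for compound 4 is 100000 nM, ranging from 20000 nM to 500000 nM, an expected step of a number no higher from compound 3 to compound 4 (the limit leaves the size open).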

Compound 4, half-maximal inhibitory concentration: > 100000 nM
Compound 4: no number, only a limit; the forecaster's own chance of this, stated with the estimate: 80%; the middle value lies on the limit itself.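

Compound 3 and compound 4 each give only a limit, so no step between them can be read: the limit of > 100000 nM in this assay, at which 4 of the 4 values shown sit.

The compounds shown leave open how strongly any of them inhibits, and whether 1-(furan-2-yl)ethyl in place of (4-methyl-1,2,5-oxadiazol-3-yl)methyl changes that at all.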